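A few compounds are considered here, and "the series" means these few. Any claim that something is new, unique, unknown or untested is made for them only; others in the source may bear on it.

Compound 1 `CCOC(=O)c1c(-c2ccccc2)nn(-c2ccccc2)c1COc1cc(OC)c(C=O)c(OC)c1` gives the highest number among the two compounds measured in an assay for inhibition of Alpha amylase (Homo sapiens), with a stated time of 30 min (on this read-out lower numbers stand for stronger inhibition and higher numbers for weaker inhibition), namely 40 ug/mL. Its nearest neighbour, compound 2 `CCOC(=O)c1c(-c2ccccc2)nn(-c2ccccc2)c1Cn1cnc2cc([N+](=O)[O-])ccc21`, gives 30 ug/mL in this assay, a gap that lies within the scatter, so the two compounds are not separated on this read-out. Compound 3 `CCOC(=O)c1c(-c2ccccc2)nn(-c2ccccc2)c1COc1ccc(C=O)cc1` differs from compound 1 by a group of 8 heavy atoms (7 carbon, 1 oxygen; one six-membered aromatic ring of carbon only) in place of a group of 12 heavy atoms (9 carbon, 3 oxygen; one six-membered aromatic ring of carbon only), on an oxygen on a saturated carbon. Among the compounds with values here, no measured pair shows what such a change does here, so only a step of no change at the digits printed from compound 1 to compound 3 (within the scatter) is expected, none beyond the scatter. In this assay compound 3 is therefore estimated at 40 ug/mL, with a range from 20 ug/mL to 80 ug/mL.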

Compound 3, half-maximal inhibitory concentration: 60 ug/mL
For compound 3 the middle estimate is 1.5-fold (0.18 log units) below the measured one, and the stated range covers the measured number.
By their numbers in this assay, from the lowest: compounds 2, 1 and 3 (each within the scatter of the next).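

In this assay, the 4-formylphenyl group on an oxygen on a saturated carbon, in place of the group of 12 heavy atoms, gives a 1.5-fold higher number from compound 1 to compound 3 (0.18 log units; within the scatter). This first pair changing one place shows that the group on this oxygen can go from 12 heavy atoms to 8 and from 3 hydrogen-bond acceptors to 1 without separating the two compounds on this read-out. Nothing at hand bears on the reason for this result. From the compounds shown here alone, it remains open whether an amine or a carboxylic acid in place of this group would give a step beyond the scatter. Whether a longer chain on this oxygen would do so is equally unresolved.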